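Chalcone series: allylic chloride to acetate

The source may hold more compounds than are shown below. What is called first, only, known or untested is meant among the compounds shown, and "the series" means these compounds.

Compound 1 `O=C(/C=C/C1CCCCC1)c1ccccc1`: 15000 nM
Compound 2 `O=C(/C(=C/c1ccccc1)CCl)c1ccccc1`: 18000 nM
Compound 3 `O=C(/C(=C/c1ccc(Cl)cc1)CCl)c1ccccc1`: 17000 nM

In a functional assay on T47D cells (Homo sapiens) for inhibition, read by sulforhodamine B assay, with a stated time of 48 h (on this read-out higher numbers stand for weaker inhibition of growth and lower numbers for stronger inhibition of growth), compound 1 gives 15000 nM, compound 2 gives 18000 nM and compound 3 gives 17000 nM. Compound 3 stands second highest of the three numbers; its gaps to compound 2 and to compound 1 are within the scatter, so no order among the three can be read. Going by the values given here, the only measured step, a 1.1-fold lower number from compound 2 to compound 3 (0.02 log units; within the scatter), concerns chloro in place of hydrogen on an aromatic carbon and does not touch the chain. Compound 4 `CC(=O)OC/C(=C\c1ccc(Cl)cc1)C(=O)c1ccccc1` differs from compound 3 by acetoxy in place of chloro on a saturated chain carbon bound to a double-bonded chain carbon. Among the compounds with values here, no measured step bears on this change. With all three numbers sitting together, the expectation for compound 4 is no step beyond the scatter, no change at the digits printed from compound 3 to compound 4 (within the scatter). Compound 4 is therefore estimated at 17000 nM, range 6000 nM to 50000 nM.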

Compound 4, concentration for 50% growth inhibition: 5300 nM
The estimate for compound 4 lay 3.2-fold (0.51 log units) above the measured number, and the stated range ends above it.
By their numbers in this assay, from the lowest: compound 4; then compounds 1, 3 and 2 (each within the scatter of the next).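

In this assay, acetoxy in place of chloro on a saturated chain carbon bound to a double-bonded chain carbon gives a 3.2-fold lower number from compound 3 to compound 4 (0.51 log units; beyond the scatter). Going by these compounds alone, this position responds to a change of group, whereas the only earlier step, on an aromatic carbon, stayed within the scatter. Nothing at hand bears on the cause of this step.

Open, going by these compounds, is whether a hydroxyl, an amine or a longer ester chain on this carbon would give a similar number. Also open, on these data alone, is whether the same change carries over to the core of compound 2.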